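The source may report more compounds than this note shows. Statements on the series, on what has been measured and on what is new or still open speak of the compounds shown alone.

Measured so far in a physicochemical assay for lipophilicity; on this read-out lower numbers stand for lower lipophilicity and higher numbers for higher lipophilicity:
- compound 1 `CNC(=O)c1cc(C(=O)N[C@H]2CC[C@H](O)CC2)n([C@@H](C)c2ccc(Cl)cc2)n1`: 3.7
- compound 2 `CCCNC(=O)c1cc(C(=O)NC)nn1[C@@H](C)c1ccccc1`: 4.4
- compound 3 `CNC(=O)c1cc(C(=O)NCCO)n([C@@H](C)c2ccccc2)n1`: 2.4

Compound 3, at 2.4, holds the lowest number of the three, clearly under both of the others. Compound 4 `CNC(=O)c1cc(C(=O)N[C@H]2CC[C@H](O)CC2)n([C@@H](C)c2ccccc2)n1` is still to be measured in this assay, and it differs from compound 3 in one place: 4-hydroxycyclohexyl in place of 2-hydroxyethyl on an amide-type nitrogen. In words, 4-hydroxycyclohexyl stands in place of 2-hydroxyethyl on an amide-type nitrogen.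

Within the data shown here, no measured step covers this exact change. Among the measured compounds shown here, the only step available, a number 2.00 log units lower from compound 2 to compound 3 (beyond the scatter), is large and shows that a change on such a chain can move this number a long way. That step swaps methyl for hydroxy, however, whereas here a hydroxy group is present on both sides of the change. Compound 1, at 3.7, offers a second guide, since it carries the same 4-hydroxycyclohexyl group. For the measured compounds named here, it also carries a chlorine that compound 4 lacks, and no measured pair isolates that difference.

A moderate rise, beyond the scatter, is therefore expected: a number 0.70 log units higher from compound 3 to compound 4 (beyond the scatter). The estimate for compound 4 is 3.1, with an expected range from 2.6 to 3.6.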

Compound 4, distribution coefficient: 2.9
Compound 4: the middle estimate sits 0.20 log units above what was measured, within the range that was stated.
By their numbers in this assay, from the lowest: compound 3; then compound 4; then compound 1; then compound 2.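

In the one assay shown here (this assay), replacing 2-hydroxyethyl with 4-hydroxycyclohexyl on the amide-type nitrogen gives a clear but modest step (a number 0.50 log units higher from compound 3 to compound 4 (beyond the scatter)), so this position still responds when a hydroxy group is present on both sides of the change and the chain gives way to a six-membered carbon ring. Set against propyl at that nitrogen, the same 4-hydroxycyclohexyl group gives a much bigger drop (a number 1.50 log units lower from compound 2 to compound 4 (beyond the scatter)), which places this ring-bearing compound well under the compound with the plain chain. Among these compounds, compound 4 also forms the first pair that isolates the chlorine of compound 1, and hydrogen in place of chloro on an aromatic carbon gives a step of its own (a number 0.80 log units lower from compound 1 to compound 4 (beyond the scatter)), showing that this read-out responds to a change away from the amide as well.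

No measurement shown here gives a reason for any of these steps. Still open, on these data alone, is how the number would move with an amine or a carboxylic acid in place of the hydroxy on the cyclohexyl ring, or with a longer chain ending in hydroxy on the same nitrogen.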